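Compound 1 to compound 4: losing the 3-carboxyazetidin-1-yl group

The compounds below may be only part of what the source reports. "The series", "measured", "known", "first", "only" and "open" are said of these compounds alone.

In an ADME assay on a cell-free system (plasma, Homo sapiens) (a lower number here means a smaller unbound share, a higher number a larger unbound share of the compound), compound 1 `CCc1c(CN2CC(C(=O)O)C2)cccc1-c1nsc(-c2ccc(CC(C)C)c(C#N)c2)n1` gives 0.0128, the highest of the three measured numbers. Compound 2 `CCc1c(CN(C)CC(=O)O)cccc1-c1nsc(-c2ccc(OC(C)C)c(C(F)(F)F)c2)n1` gives 0.0049, and compound 3 `CCc1c(CN(C)C(C)(C)C(=O)O)cccc1-c1nsc(-c2ccc(OC(C)C)c(C(F)(F)F)c2)n1` lies much lower at 0.00004. Compound 1 and compound 2 differ in more than one place, so their gap isolates no single group.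

The change under review leads to compound 4 `CCc1c(CCCC(=O)O)cccc1-c1nsc(-c2ccc(CC(C)C)c(C#N)c2)n1`: 2-carboxyethyl in place of 3-carboxyazetidin-1-yl on a saturated chain carbon bound to an aromatic carbon. Cut one bond further out, the same difference reads (3-carboxyazetidin-1-yl)methyl to 3-carboxypropyl.

Among the compounds with values here, only one measured step bears on this part of the structure: a 120-fold lower number from compound 2 to compound 3 (2.09 log units; beyond the scatter). It shows that the unbound fraction can move strongly with the group carrying the acid, but it is a different change and it keeps the amine nitrogen. Within the data shown here, all three measured compounds carry an amine nitrogen and compound 4 has none, so no measured step covers this replacement directly. The direction therefore rests on weak evidence: compound 1 holds the top value at 0.0128, so a fall is more likely than a rise. Among the measured compounds shown here, the expected change is a 3.7-fold lower number from compound 1 to compound 4 (0.56 log units; beyond the scatter), far smaller than the one measured step. For compound 4 the estimate is 0.0035, with an expected range of 0.0008 to 0.012.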

Compound 4, unbound fraction: 0.0003
Beside the measured number, compound 4's estimate is 12-fold (1.07 log units) above it; the measured number lies below the stated range.
By their numbers in this assay, from the lowest: compound 3; then compound 4; then compound 2; then compound 1.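

Replacing 3-carboxyazetidin-1-yl with 2-carboxyethyl on a saturated chain carbon bound to an aromatic carbon gives a 43-fold lower number from compound 1 to compound 4 (1.63 log units; beyond the scatter) in this assay. The carboxy group is present on both sides, so a change that removes the amine nitrogen and the four-membered ring while keeping the acid is enough for a large step. With a 120-fold lower number from compound 2 to compound 3 (2.09 log units; beyond the scatter) as the other large step, the series now shows strong movement from two different edits of the acid-bearing group, one keeping the amine nitrogen and one losing it, and no measured data bearing on the cause of this fall are available.

The single step changes the amine nitrogen and the four-membered ring together, so the compounds shown do not assign the fall to either feature. On the core of compound 1, a 3-carboxycyclobutyl group would keep the four-membered ring without the nitrogen, and an open-chain amine carrying a carboxymethyl group would keep the nitrogen without the ring, so this pair could separate the two contributions.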